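The compounds below may be only part of what the source reports. "The series", "measured", "known", "first", "only" and "open" are said of these compounds alone.

Measured so far:
compound 1 `CC1=CC[C@H](C(C)C)c2cc(C)c(OC(=O)c3ccc(C)cc3)cc21` — 65%
compound 2 `CC1=CC[C@H](C(C)C)c2cc(C)c(OC(=O)Nc3ccccc3)cc21` — 75.1%

In a functional assay on MCF7 cells (Homo sapiens) for antiproliferative activity, read by sulforhodamine B assay, with a stated time of 48 h, tested at 50 uM (a higher number here means more inhibition at the concentration tested (going by the name of the read-out), a lower number less inhibition), compound 2 stands highest of the two numbers; its nearest neighbour is compound 1, and the step of a number 10.1 percentage points higher from compound 1 to compound 2 (beyond the scatter) lies beyond the scatter, though it is a modest one. The next compound, compound 3 `CC1=CC[C@H](C(C)C)c2cc(C)c(OC(=O)c3ccc([N+](=O)[O-])cc3)cc21`, differs from compound 2 in one place: 4-nitrophenyl in place of anilino on a carbonyl carbon.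

Among the measured compounds shown here, only one measured step bears on this change, and only indirectly. The step of a number 10.1 percentage points higher from compound 1 to compound 2 (beyond the scatter) shows what replacing an aryl group on the carbonyl carbon by anilino did; compound 3 moves back to an aryl group on that carbon, so the expected direction is the reverse of that step, of a similar modest size. For the measured compounds named here, compound 3 is therefore expected to give about 65%, within a range of 45% to 85%, which would mean a step of a number 10.1 percentage points lower from compound 2 to compound 3 (beyond the scatter); the range is wide, as no measured compound carries the 4-nitrophenyl group.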

Compound 3, a percentage reported as inhibition, at one concentration (the size of the read-out at that concentration, not a potency): 72.9%
The estimate for compound 3 lay 7.9 percentage points below the measured number; low and high end bracket the measured number.
By their numbers in this assay, from the lowest: compounds 1, 3 and 2 (each within the scatter of the next, the first and the last beyond it).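

In this assay, 4-nitrophenyl in place of anilino on the carbonyl carbon gives a number 2.2 percentage points lower from compound 2 to compound 3 (within the scatter), so the loss of the hydrogen-bond donor counted on anilino does not separate these two compounds. Nitro in place of methyl on an aromatic carbon gives a number 7.9 percentage points higher from compound 1 to compound 3 (within the scatter), so the two aryl groups cannot be told apart either, and the gain seen with anilino over 4-methylphenyl does not amount to a general edge of anilino over aryl groups, with the 4-nitrophenyl compound standing against such a reading. Nothing available here accounts for these numbers.

As far as these compounds go, it remains open whether any ring is needed on this carbonyl carbon, which a plain methyl group or a dimethylamino group there would address. Also open, from the compounds shown here alone, is how a carboxylic acid or a methoxy group on the aromatic ring would compare with nitro and methyl.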